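This account rests on a few compounds, and the source may have more. Where it says the series, first, only, none or still open, it means among the compounds named here.

Of the compounds shown here, two have been measured in a functional assay on OVCAR-4 cells (Homo sapiens) for inhibition, read by sulforhodamine B assay, with a stated time of 48 h, tested at 10 uM; a lower number here means a stronger effect, a higher number a weaker effect of the compound at the concentration tested. Compound 1 `COc1cc(Cl)cc(-c2nn(-c3cccc(NC(=O)Nc4ccc(Cl)c(C(F)(F)F)c4)c3)cc2-c2ccncc2)c1` gives 16.6%. Compound 2 `COc1cc(Cl)cc(-c2nn(-c3cccc(NC(=O)Nc4ccc(Cl)c(Cl)c4)c3)cc2-c2ccncc2)c1`, with a chloro in place of the trifluoromethyl on an aromatic carbon, gives 13.3%. The step of a number 3.3 percentage points lower from compound 1 to compound 2 (within the scatter) lies within the scatter, so the two compounds cannot be told apart on these numbers, and compound 2 simply sits at one of two closely matched values, both showing a strong effect at the concentration tested.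

Compound 3 `COc1cc(Cl)cc(-c2nn(-c3cccc(NC(=O)c4cccc(C(F)(F)F)c4)c3)cc2-c2ccncc2)c1` has not been measured. It differs from compound 2 by 3-(trifluoromethyl)phenyl in place of (3,4-dichlorophenyl)amino on a carbonyl carbon; the group that leaves carries a hydrogen-bond donor, the group that enters carries none, and the change sits on the carbonyl carbon itself. For the measured compounds named here, no measured step covers a change of this kind. Going by the values given here, the only step available, from compound 1 to compound 2, exchanges one substituent for another and stays within the scatter, so it offers no guide here. The expectation therefore rests on little, and a step upward of a number 18.7 percentage points higher from compound 2 to compound 3 (beyond the scatter) in this assay, meaning a somewhat weaker effect, is estimated with wide uncertainty. Compound 3 is expected to give 32%, within 10% to 65%.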

Compound 3, a percentage reported as activity, at one concentration (the size of the read-out at that concentration, not a potency): 71.8%
Compound 3: middle estimate off by 39.8 percentage points, on the low side; measured number above the stated range.
By their numbers in this assay, from the lowest: compounds 2 and 1 (each within the scatter of the next); then compound 3.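

In this assay, the carbonyl carbon proves far more sensitive than the earlier comparison suggested: putting 3-(trifluoromethyl)phenyl in place of (3,4-dichlorophenyl)amino gives a number 58.5 percentage points higher from compound 2 to compound 3 (beyond the scatter), and putting it in place of (4-chloro-3-(trifluoromethyl)phenyl)amino gives a number 55.2 percentage points higher from compound 1 to compound 3 (beyond the scatter). Both steps mean a much weaker effect at the concentration tested, whereas exchanging trifluoromethyl for chloro on the ring of the amino group left the read-out within the scatter, so this part of the molecule tolerates one kind of change and not the other. Nothing available explains why this change weakens the effect so strongly.

Each large step removes the amino nitrogen with its hydrogen-bond donor and alters the substituents on the aromatic ring at the same time, so the compounds shown cannot separate these two changes. From the compounds shown here alone, it remains open how the read-out would respond to a (3,4-dichlorophenyl)methyl group on the same carbonyl carbon, which would keep the dichlorinated ring but have a carbon in place of the amino nitrogen.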